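Amide series on the shared core: compound 1 to compound 4

The compounds below may be only part of what the source reports. "The series", "measured", "known", "first", "only" and "open" are said of these compounds alone.

Compound 1 `COc1ccc2c(=O)c(/C=C/C(=O)Nc3ccccc3Cl)coc2c1`: in a functional assay on Huh-7 cells (Homo sapiens) for inhibition, read by MTT assay, with a stated time of 48 h (a lower number here means a stronger inhibitor, a higher number a weaker inhibitor), compound 1 gives 58400 nM.
Compound 2 `O=C(/C=C/c1coc2cc(O)ccc2c1=O)NCc1ccc(F)cc1`: in this assay compound 2 reaches only a limit, > 100000 nM.
Compound 3 `Cc1ccc(CNC(=O)/C=C/c2coc3cc(O)ccc3c2=O)cc1`: in this assay compound 3 reaches only a limit, > 100000 nM.

Among the compounds with values here, compound 1 holds the only number in the set; the other two values are limits. The step from compound 2 to compound 3 is a step that the two limits leave unreadable from compound 2 to compound 3 because both sit at the limit of > 100000 nM in this assay, at which 2 of the 3 values shown sit. Compound 4 `CCOc1ccc(NC(=O)/C=C/c2coc3cc(OC)ccc3c2=O)cc1` differs from compound 1 by 4-ethoxyphenyl in place of 2-chlorophenyl on an amide-type nitrogen. Within the data shown here, no measured step bears on this amide-side change: the only step in the set, the one just noted, is unreadable. The change is therefore expected to move compound 4 by no change at the digits printed from compound 1 to compound 4 (within the scatter), nothing beyond the scatter. Compound 4 is estimated at 58400 nM, within 20000 nM to 170000 nM, with a real chance that this assay reports only a limit.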

Compound 4, half-maximal inhibitory concentration: 3230 nM
For compound 4 the middle estimate is 18-fold (1.26 log units) above the measured one; the whole stated range lies above it.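

Exchanging 2-chlorophenyl for 4-ethoxyphenyl on the amide-type nitrogen gives an 18-fold lower number from compound 1 to compound 4 (1.26 log units; beyond the scatter) in this assay, so this position clearly affects the read-out. Within the data shown here, this is the only readable step so far; the step between compound 2 and compound 3 cannot be read because both values are limits: the limit of > 100000 nM in this assay, at which 2 of the 4 values shown sit. No measurement shown accounts for the size of the step. Still open, from the compounds shown here alone, is whether the step follows the entering ethoxy group or the departing chlorine. Also open, going by these compounds, is how a propoxy chain or a carboxylic acid in place of the ethoxy group would read.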